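A few compounds are considered here, and "the series" means these few. Any claim that something is new, unique, unknown or untested is made for them only; others in the source may bear on it.

Measured compounds in an ADME assay on MCF-10A cells (Homo sapiens) for antiproliferative activity, read by sulforhodamine B assay, with a stated time of 48 h; on this read-out lower numbers stand for stronger inhibition and higher numbers for weaker inhibition:
Compound 1 `CC1(C)[C@@H]2CC3=N[C@@H](CCC(=O)O)C(=O)O[C@@]3(C)[C@H]1C2` gives > 1200000 nM, a limit of the assay.
Compound 2 `CC1(C)N=C2C[C@H]3C[C@H](C3(C)C)[C@@]2(C)OC1=O` gives > 2000000 nM, also a limit.
Compound 3 `CC1(C)[C@H]2CC3=N[C@H](CCC(=O)O)C(=O)O[C@]3(C)[C@@H]1C2` gives > 1200000 nM, also a limit.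

Compound 1 therefore stands only at a limit in this assay, with no number of its own. Compound 4 `CC(C)(C)OC(=O)CC[C@@H]1N=C2C[C@@H]3C[C@@H](C3(C)C)[C@]2(C)OC1=O` differs from compound 1 by tert-butyl in place of hydrogen on an oxygen next to a carbonyl group. For the measured compounds named here, the single measured one-place step, a step that the two limits leave unreadable from compound 1 to compound 3, cannot be read from its two limits, and it concerns configuration only (the fact that compounds 1 and 3 differ only in the configuration as drawn); no measured step touches the ester. With every value shown sitting at a limit of > 1200000 nM in this assay, at which 2 of the 3 values shown sit (the limit of > 2000000 nM in this assay, at which 1 of the 3 values shown sits), the step of a number no higher from compound 1 to compound 4 (the limit leaves the size open) is expected to show none beyond the scatter, most likely as a further limit. Compound 4 is estimated at 1200000 nM, within 300000 nM to 3000000 nM.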

Compound 4, half-maximal inhibitory concentration: > 1000000 nM
Compound 4: a limit, no number; the forecaster's own chance of this, stated with the estimate: 80%; the middle value lies beyond the limit too.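

Compound 4 gives > 1000000 nM, which is a limit; compound 1 also stands only at a limit, so the step between them cannot be read. The compounds shown leave open what size of effect, if any, tert-butyl in place of hydrogen has.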